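Benzyl to 3-methoxyphenyl: three limits, no readable steps

The compounds below may be only part of what the source reports. "The series", "measured", "known", "first", "only" and "open" are said of these compounds alone.

In a functional assay on HepG2 cells (Homo sapiens) for antiproliferative activity, read by MTT assay, with a stated time of 48 h (on this read-out lower numbers stand for stronger inhibition and higher numbers for weaker inhibition), compound 3 `CCOC(=O)CNc1nc(NCc2ccccc2)ncc1[N+](=O)[O-]` gives only a limit of the assay, > 100000 nM. Compound 1 `COC(=O)CN(C)c1nc(NCc2ccccc2)ncc1[N+](=O)[O-]` likewise reaches only a limit, > 100000 nM. Compound 2 `CCOC(=O)CNc1nc(Nc2ccc(Cl)cc2)ncc1[N+](=O)[O-]` also stops at a limit, > 100000 nM. All three values sit at the limit of > 100000 nM in this assay, at which 3 of the 3 values shown sit, so compound 3 cannot be placed against its neighbours. The step from compound 3 to compound 4 `CCOC(=O)CNc1nc(Nc2cccc(OC)c2)ncc1[N+](=O)[O-]` is 3-methoxyphenyl in place of benzyl on a nitrogen on an aromatic ring. Among the measured compounds shown here, two measured steps touch it: a step that the two limits leave unreadable from compound 1 to compound 3 and a step that the two limits leave unreadable from compound 2 to compound 3; neither has a readable size, as both of their ends are limits. Compound 2 already carries 4-chlorophenyl on that nitrogen and shows only a limit, so no step beyond the scatter is expected in this assay. Compound 4 is therefore estimated at 150000 nM, between 30000 nM and 600000 nM. The expected step is a step that the limit leaves unreadable from compound 3 to compound 4, small and most likely ending in a limit again.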

Compound 4, half-maximal inhibitory concentration: > 100000 nM
Compound 4 gave a limit, no number (the forecaster's own chance of this, stated with the estimate: 75%); the middle value lies beyond the limit too.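

Neither step into compound 4, from compound 2 or from compound 3, can be read, as all these values are limits: the limit of > 100000 nM in this assay, at which 4 of the 4 values shown sit.

The compounds shown leave open which change to the shared core, if any, would give a measurable value in this assay.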